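The compounds below may be only part of what the source reports. "The series", "measured", "known", "first", "only" and "open" are said of these compounds alone.

Of the compounds shown here, two that share one core have been measured in an ADME assay (liver) for metabolic stability, with Liver microsome (Homo sapiens) as the target, using microsomes and NADPH, with a stated time of 30 min, tested at 1 uM; on this read-out higher numbers stand for fast clearance and lower numbers for slow clearance. Compound 1 `CS(=O)(=O)Nc1cccc(-c2cc(C(O)(C(F)(F)F)C(F)(F)F)cnc2N2CCN(S(=O)(=O)c3ccc(N)nc3)CC2)c1` gives 40 mL.min-1.g-1, and compound 2 `COc1ccc(-c2cc(C(O)(C(F)(F)F)C(F)(F)F)cnc2N2CCN(S(=O)(=O)c3ccc(N)nc3)CC2)cn1` gives 25 mL.min-1.g-1. These two numbers lie within the usual scatter of each other, so compound 2 cannot be told apart from compound 1 here.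

Compound 3 `Nc1ccc(S(=O)(=O)N2CCN(c3ncc(C(O)(C(F)(F)F)C(F)(F)F)cc3-c3cccc4[nH]ncc34)CC2)cn1` keeps the core and differs at the same aromatic carbon: 1H-indazol-4-yl in place of 6-methoxypyridin-3-yl on an aromatic carbon. Within the data shown here, only one measured step bears on this change, a 1.6-fold lower number from compound 1 to compound 2 (0.20 log units; within the scatter), where 6-methoxypyridin-3-yl took the place of 3-(methanesulfonamido)phenyl at that carbon. That step lies within the scatter. Among the measured compounds shown here, it is a single example, though, and no measured compound carries 1H-indazol-4-yl, so the data give only weak guidance and the range must stay wide.

For the measured compounds named here, with that one exchange at this carbon as the sole guide, no shift beyond the scatter is expected. The estimated size is a 1.2-fold higher number from compound 2 to compound 3 (0.08 log units; within the scatter). In this assay, compound 3 is expected at 30 mL.min-1.g-1, with an estimated range from 13 mL.min-1.g-1 to 70 mL.min-1.g-1.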

Compound 3, intrinsic clearance in microsomes: 42 mL.min-1.g-1
The estimate for compound 3 lay 1.4-fold (0.15 log units) below the measured number, within the range that was stated.
By their numbers in this assay, from the lowest: compounds 2, 1 and 3 (each within the scatter of the next).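

In this assay, three rather different groups have now stood on this aromatic carbon, ortho to a large group, and they cannot be told apart: the step of a 1.7-fold higher number from compound 2 to compound 3 (0.23 log units; within the scatter) and the step of a 1.1-fold higher number from compound 1 to compound 3 (0.02 log units; within the scatter) both lie within the scatter. The 1H-indazol-4-yl group brings a five-membered aromatic ring, which neither earlier group has, yet its arrival gives no shift that can be separated from the noise, so the lone earlier exchange at this carbon is no longer the only one of its kind. No separate measurement is available to explain this flat picture.

From the compounds shown here alone, all three groups are aromatic rings, so it remains open whether this carbon would tolerate a non-aromatic group just as evenly, such as a primary amine, a carboxylic acid or a short alkyl chain. The compounds also share the rest of the core, so they cannot show whether the same holds once another part of the molecule is changed.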